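A few compounds are considered here, and "the series" means these few. Any claim that something is new, unique, unknown or untested is made for them only; others in the source may bear on it.

Measured compounds in an assay on lysate for inhibition of phosphatidylcholine:ceramide cholinephosphotransferase 2 (Homo sapiens), read by HPLC, with stated times of 30 min and 2 h; on this read-out lower numbers stand for stronger inhibition and higher numbers for weaker inhibition:
- compound 1 `Cc1ccccc1COc1ccccc1C(=O)Nc1cccnc1` gives 1500 nM
- compound 2 `O=C(Nc1cccnc1)c1ccccc1OCc1c(F)cccc1Cl` gives 1500 nM

Compound 1 stands level with compound 2 at the digits shown; the one step recorded in this assay, from compound 1 to compound 2, is no change at the digits printed from compound 1 to compound 2 (within the scatter), a swap of 2-chloro-6-fluorophenyl for 2-methylphenyl on the saturated chain carbon bound to the aryl oxygen. That change left the read-out where it was.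

Compound 3 `O=C(Nc1cccnc1)c1ccccc1OCc1ccccc1OCCCCCCCl` is not yet measured. It differs from compound 1 by (6-chlorohexyl)oxy in place of methyl on an aromatic carbon, ortho to a large group. For the measured compounds named here, no measured step touches this position in this way; the only step available, no change at the digits printed from compound 1 to compound 2 (within the scatter), changed the substituents on that same outer ring without moving the number, which suggests that ring tolerates variation, but it says nothing about a long chain carrying an extra acceptor. The expectation for compound 3 is therefore a step of a 1.3-fold lower number from compound 1 to compound 3 (0.10 log units; within the scatter) in this assay, no clear direction beyond the scatter. Compound 3 is estimated at 1200 nM, with a range from 300 nM to 5000 nM.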

Compound 3, half-maximal inhibitory concentration: 470 nM
For compound 3 the middle estimate is 2.6-fold (0.41 log units) above the measured one; measured number inside the range.
By their numbers in this assay, from the lowest: compound 3; then compounds 1 and 2 (each within the scatter of the next).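

In this assay, the change of (6-chlorohexyl)oxy in place of methyl on an aromatic carbon, ortho to a large group, gives a 3.2-fold lower number from compound 1 to compound 3 (0.50 log units; beyond the scatter) and is a modest gain. For the compounds shown here, this is the first change to move the number beyond the scatter, whereas no change at the digits printed from compound 1 to compound 2 (within the scatter) showed only that the outer ring accepts a different pair of substituents with no visible effect. The position therefore accepts a chain far larger than methyl with no loss and does respond to what it carries, but nothing available explains the gain.

A single step cannot separate the contributions of the ether oxygen, the chain length and the chlorine, so methoxy, hexyloxy without the chlorine, a longer chain, and chains ending in an amine or a carboxylic acid would each test a different part of the group. From the compounds shown here alone, it also remains open whether the same gain would appear on the 2-chloro-6-fluorophenyl ring of compound 2, and whether other changes to the shared core would leave it intact.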